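Ethoxy for Ethyl: Cytotoxicity Outlook for Compound 3

The compounds below may be only part of what the source reports. "The series", "measured", "known", "first", "only" and "open" are said of these compounds alone.

Two compounds share a core carrying a uracil-bearing ether chain. Compound 1 `N#Cc1ccc2c(F)cc(Oc3ccccc3OCCn3ccc(=O)[nH]c3=O)c(Cl)c2c1` was tested in a toxicity assay on MT2 cells (Homo sapiens) for cytotoxicity, read by MTT assay; on this read-out lower numbers stand for higher toxicity in this test and higher numbers for lower toxicity in this test. For compound 1 the result is only a limit of the assay, > 100000 nM, not a number. Within the data shown here, compound 2 `CCc1cc(Oc2ccccc2OCCn2ccc(=O)[nH]c2=O)c(C)c2cc(C#N)ccc12` gives 12000 nM in this assay, which is the only actual number among the two results. The other result, that of compound 1, sits at the limit, as the limit of > 100000 nM in this assay, at which 1 of the 2 values shown sits, records. Compound 3 `CCOc1cc(Oc2ccccc2OCCn2ccc(=O)[nH]c2=O)c(C)c2cc(C#N)ccc12` carries the change (ethoxy in place of ethyl on an aromatic carbon). Among the measured compounds shown here, no measured pair shows the effect of such a change, so no measured step can be pointed to. The step from compound 2 to compound 3 in this assay is expected to be small, a 1.7-fold higher number from compound 2 to compound 3 (0.22 log units; within the scatter), likely within the usual scatter or leaning toward lower toxicity. Compound 3 is estimated at 20000 nM, with a range from 6000 nM to 80000 nM.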

Compound 3, half-maximal cytotoxic concentration: > 100000 nM
Compound 3 gave a limit, no number; the forecaster's own chance of this, stated with the estimate: 25%; middle value at least 5.0-fold (0.69 log units) away from the limit.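

Among these compounds, the carbon para to a methyl group proves sensitive on this read-out, something the earlier compounds could not show. In this assay, ethoxy in place of ethyl gives an at least 8.3-fold higher number from compound 2 to compound 3 (0.92 log units; beyond the scatter), a shift toward lower toxicity in this test from a swap that adds just one oxygen. The value of compound 3 is a limit of the assay and not a number, so the true size of the step stays unknown, and the series now has few real numbers to work with: the limit of > 100000 nM in this assay, at which 2 of the 3 values shown sit.

This single pair cannot separate the effect of the oxygen from that of the longer group, since both change together. A propyl chain or a methoxy group on the same carbon would help tell these apart, and an amine there would test a different kind of atom.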